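A few compounds are considered here, and "the series" means these few. Any claim that something is new, unique, unknown or untested is made for them only; others in the source may bear on it.

Three compounds of one series have been examined for their ability to activate Jurkat cells, and a fourth remains to be tested. Compound 1 `O=[N+]([O-])c1ccc(NCc2ccccc2O)cc1` carries a nitro group on the aryl ring; in a functional assay on Jurkat cells (Homo sapiens) for activation, with a stated time of 24 h (on this read-out higher numbers stand for an effect only at larger amounts of compound and lower numbers for an effect already at smaller amounts), compound 1 is reported as "not active" (no number reported), with no number given. Compound 2 `Oc1ccc(-c2ccc(NCc3ccccc3O)cc2)cc1` bears a hydroxyphenyl group in place of the nitro group, and in this assay compound 2 is likewise reported as "not active" (no number reported), again without a number. Compound 3 `Oc1ccccc1CNc1ccc(-c2ccccc2F)cc1` carries a fluorophenyl group instead, and in this assay compound 3 gives 2150 nM. Among the measured compounds shown here, compound 3 therefore stands as the only member of the set with a measured number; the other two entries remain without one.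

Compound 4 `N#Cc1ccccc1-c1ccc(NCc2ccccc2O)cc1` differs from compound 3 in a single place: cyano in place of fluoro on an aromatic carbon. For the measured compounds named here, no pair of measured compounds differing in one place is available, so there is no measured step to lean on. Given the single number for compound 3, the step from compound 3 to compound 4 is expected to stay modest, a 1.0-fold higher number from compound 3 to compound 4 (0.01 log units; within the scatter), with no clear direction beyond the usual scatter. Compound 4 is accordingly estimated at 2200 nM in this assay, within a range of 700 nM to 7000 nM.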

Compound 4, half-maximal effective concentration: "not active" (no number reported)
The entry for compound 4 holds no number; there is nothing to compare the estimate with.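

Compound 4, like compounds 1 and 2, has no number, so no step can be read from compound 3 to compound 4. The compounds shown leave open how cyano and fluoro compare at this place, beyond compound 3 giving 2150 nM. Nothing shown offers any explanation for the result.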